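The source may hold more compounds than are shown below. What is called first, only, known or untested is meant among the compounds shown, and "the series" means these compounds.

Measured in a functional assay on U-251 cells (Homo sapiens) for antiproliferative activity, read by MTT assay, with a stated time of 48 h; a higher number here means a weaker inhibitor, a lower number a stronger inhibitor:
- Compound 1 `COc1ccc(-c2nc3cccc(-c4cc(OC)c(OC)c(OC)c4)c3o2)cc1F`: 1700 nM
- Compound 2 `COc1cc(-c2cccc3nc(-c4ccc(N)cc4)oc23)cc(OC)c1OC`: 1040 nM

Compound 2, at 1040 nM, cannot be separated from compound 1, at 1700 nM, as the two numbers lie within the scatter of each other. Compound 3 `COc1cc(-c2cccc3nc(-c4cccc(N)c4)oc23)cc(OC)c1OC` has the same atoms as compound 2, joined differently: 3-aminophenyl in place of 4-aminophenyl on an aromatic carbon. It carries 3-aminophenyl in place of 4-aminophenyl, on an aromatic carbon of a five-membered aromatic ring with 1 nitrogen and 1 oxygen.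

Within the data shown here, only one measured step bears on this change. It alters the group at that same place, and in this assay it amounts to a 1.6-fold lower number from compound 1 to compound 2 (0.21 log units; within the scatter). Among the measured compounds shown here, that step exchanges two different groups, and no measured pair moves the amino group itself, so the evidence is indirect. With compound 2 and compound 1 this close, no step beyond the scatter is expected, and no direction is favoured with any confidence. The expected change is a 1.2-fold higher number from compound 2 to compound 3 (0.06 log units; within the scatter). Compound 3 is estimated at 1200 nM, with an expected range from 450 nM to 3200 nM.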

Compound 3, half-maximal inhibitory concentration: 2200 nM
The estimate for compound 3 lay 1.8-fold (0.26 log units) below the measured number, within the range that was stated.
By their numbers in this assay, from the lowest: compounds 2, 1 and 3 (each within the scatter of the next, the first and the last beyond it).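

Moving the amino group around the phenyl ring, with nothing else altered, is the only direct test of its place shown in this assay, and it gives a 2.1-fold higher number from compound 2 to compound 3 (0.33 log units; beyond the scatter) as a modest step just beyond the scatter. At this aromatic carbon of a five-membered aromatic ring with 1 nitrogen and 1 oxygen, 4-aminophenyl and 3-aminophenyl are therefore not fully interchangeable, although the gap is small, while the comparison with the 3-fluoro-4-methoxyphenyl group gives a 1.3-fold higher number from compound 1 to compound 3 (0.11 log units; within the scatter) and so does not separate 3-aminophenyl from that group. Nothing given here accounts for the difference between the two aminophenyl groups.

The compounds shown leave open whether a dimethylamino group, an acetamide or a carboxylic acid in place of the amino group would respond to the same shift around the phenyl ring. Because this reading rests on a single pair, they also leave open whether the same order of the two aminophenyl groups would hold on a different core.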